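Benzoyl in place of vinyl on the thioether chain

This account rests on a few compounds, and the source may have more. Where it says the series, first, only, none or still open, it means among the compounds named here.

Measured compounds:
Compound 1, `C=CCSc1nnc(CCC)n1N1C(=O)c2ccccc2C1=O`: in a functional assay on PC-3M cells (Homo sapiens) for cytotoxicity, read by MTT assay, with a stated time of 48 h (a lower number here means a stronger inhibitor, a higher number a weaker inhibitor), compound 1 gives > 200000 nM, which is a limit of the assay and not a number.
Compound 2, `C=CCSc1nnc(-c2cc(OC)c(OC)c(OC)c2)n1N1C(=O)c2ccccc2C1=O`: in this assay compound 2 gives > 200000 nM, again a limit of the assay rather than a number.

Compound 2 therefore stands at the limit, and so does every value shown; the limit of > 200000 nM in this assay, at which 2 of the 2 values shown sit, sums this up. Going by the values given here, no step between measured compounds is available, since the two values are both limits and cannot be compared.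

Compound 3, `COc1cc(-c2nnc(SCC(=O)c3ccccc3)n2N2C(=O)c3ccccc3C2=O)cc(OC)c1OC`, has not yet been tested in this assay. It differs from compound 2 in one place: benzoyl in place of vinyl on a saturated chain carbon bound to a sulfur. There is nothing in the measured pair that tells how this change will read, so the size of the step from compound 2 to compound 3 in this assay cannot be drawn from them. The expectation is that compound 3 most likely also sits at or near the limit, with a modest chance of a measurable number; the estimate for compound 3 is 150000 nM, within 30000 nM to 500000 nM, which is expected to mean a step of an at least 1.3-fold lower number from compound 2 to compound 3 (0.12 log units; that floor lies within the scatter).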

Compound 3, half-maximal inhibitory concentration: > 200000 nM
Compound 3 was reported as a limit (the forecaster's own chance of this, stated with the estimate: 60%); middle value at least 1.3-fold (0.12 log units) from the limit.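

In this assay compound 3 gives > 200000 nM as a limit of the assay and not a number. Going by these compounds alone, compound 2 also stands at a limit, so no step from compound 2 to compound 3 can be read: the limit of > 200000 nM in this assay, at which 3 of the 3 values shown sit. The compounds shown leave open whether benzoyl in place of vinyl on this chain changes the cytotoxicity at all.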